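Replacing methoxy with fluoro: compound 1 to compound 4

The source may report more compounds than this note shows. Statements on the series, on what has been measured and on what is new or still open speak of the compounds shown alone.

For the measured compounds named here, compound 1 `COc1ccccc1S(=O)(=O)c1cccc(N)c1C#N` gives 146000 nM in a functional assay on MT4 cells (Homo sapiens) for cytotoxicity (on this read-out higher numbers stand for weaker inhibition and lower numbers for stronger inhibition), and this is the only true number so far. Compound 2 `COc1ccc(S(=O)(=O)c2cccc(N)c2C#N)cc1` reads > 200000 nM, which is a limit and not a number. Compound 3 `N#Cc1c(N)cccc1S(=O)(=O)c1ccc(Cl)cc1` reads > 5000 nM, which is also a limit and not a number.

The next compound to be measured is compound 4 `N#Cc1c(N)cccc1S(=O)(=O)c1ccccc1F`, which keeps the shared core of compound 1. The change is fluoro in place of methoxy on an aromatic carbon, ortho to a large group: fluoro in place of methoxy on an aromatic carbon.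

Going by the values given here, one measured step bears on this, as it also replaces methoxy on an aromatic carbon, though with chloro: a step that the two limits leave unreadable from compound 2 to compound 3. It has no readable size, so it offers neither a magnitude nor a direction for the present change. The expectation therefore rests on compound 1 at 146000 nM, with no shift beyond the scatter assumed and a wide margin kept on both sides. The expected change is a 1.1-fold lower number from compound 1 to compound 4 (0.05 log units; within the scatter). A limit rather than a number is also a real possibility for the new measurement in this assay. For compound 4 the estimated value is 130000 nM, with an expected range of 40000 nM to 300000 nM.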

Compound 4, half-maximal inhibitory concentration: 57000 nM
The estimate for compound 4 lay 2.3-fold (0.36 log units) above the measured number; the measured number falls inside the stated range.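

In this assay, for the compounds shown here, fluoro in place of methoxy on an aromatic carbon, ortho to a large group, gives a 2.6-fold lower number from compound 1 to compound 4 (0.41 log units; beyond the scatter), the first step that can be read, and a modest one. At this position, then, the replacement moves the read-out beyond the scatter towards stronger inhibition in this cytotoxicity measure, and compound 4 gives a true number rather than a limit. Going by these compounds alone, the only earlier step, chloro in place of methoxy on an aromatic carbon, cannot be read: both of its ends are limits of the assay and not numbers, so it gave neither a size nor a direction.

No measurement shown bears on the cause of the new step. As far as these compounds go, it remains open whether a chloro, a hydroxy, an amine or a carboxylic acid at this same position would move the number as fluoro does, and a single readable pair sets no trend for the shared core.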